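Compound 1 to compound 3: a larger group on the core

The source may hold more compounds than are shown below. What is called first, only, known or untested is meant among the compounds shown, and "the series" means these compounds.

Compound 1 `CC(C)=Cc1nc(Nc2cccc(C(F)(F)F)c2)c2cc([N+](=O)[O-])ccc2n1`: > 125000 nM, a limit
Compound 2 `CC(C)=Cc1nc(Nc2cccc(Br)c2)c2cc([N+](=O)[O-])ccc2n1`: > 62000 nM, a limit

In a functional assay on K562 cells (Homo sapiens) for cytotoxicity, read by flow cytometry, with a stated time of 72 h (on this read-out lower numbers stand for stronger inhibition and higher numbers for weaker inhibition), compound 1 stands only at a limit, > 125000 nM. Compound 2 likewise gives only a limit, > 62000 nM. Among the measured compounds shown here, the single measured step, a step that the two limits leave unreadable from compound 1 to compound 2, has no readable size and changes another group, so it offers nothing to carry over. Compound 3 `Cc1ccc(S(=O)(=O)Cc2nc(Nc3cccc(C(F)(F)F)c3)c3cc([N+](=O)[O-])ccc3n2)cc1` differs from compound 1 thus: ((4-methylphenyl)sulfonyl)methyl in place of 2-methylprop-1-en-1-yl on an aromatic carbon. The step expected in this assay is an at least 2.5-fold lower number from compound 1 to compound 3 (0.39 log units; beyond the scatter), an uncertain estimate with the direction toward stronger inhibition, if a number can be read at all. For compound 3 the estimated value is 50000 nM, with an expected range from 10000 nM to 150000 nM.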

Compound 3, half-maximal inhibitory concentration: > 125000 nM
Compound 3 was reported as a limit; the forecaster's own chance of this, stated with the estimate: 60%; middle value at least 2.5-fold (0.39 log units) from the limit.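

Compound 1 and compound 3 both stand only at a limit in this assay, so no step between them can be read: the limit of > 125000 nM in this assay, at which 2 of the 3 values shown sit.

The compounds shown leave open whether ((4-methylphenyl)sulfonyl)methyl on the shared core changes the number at all.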